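Quinolin-3-yl in place of 1H-indol-6-yl

The compounds below may be only part of what the source reports. "The series", "measured", "known", "first", "only" and "open" are said of these compounds alone.

In a functional assay on HeLa cells (Homo sapiens) for cytotoxicity, read by MTT assay, with a stated time of 48 h (a lower number here means a stronger inhibitor, a higher number a weaker inhibitor), compound 1 (`COc1ccc(-c2nc3ccccn3c2C(=O)/C=C\Nc2cnc3ccccc3c2)cc1`) gives 9440 nM and compound 2 (`O=C(/C=C\Nc1ccc2cc[nH]c2c1)c1c(-c2ccc(Cl)cc2)nc2ccccn12`) gives 10900 nM so compound 2 stands level with compound 1 within the scatter. Compound 3 (`O=C(/C=C\Nc1cnc2ccccc2c1)c1c(-c2ccc(Cl)cc2)nc2ccccn12`) has quinolin-3-yl in place of 1H-indol-6-yl on an amine nitrogen. Within the data shown here, no measured pair isolates this change. Compound 1 also carries quinolin-3-yl and gives 9440 nM so no step beyond the scatter is expected in this assay for this change. The expected size is a 1.1-fold lower number from compound 2 to compound 3 (0.06 log units; within the scatter) and remains an estimate. Compound 3 is estimated at 9500 nM with an expected range of 4500 nM to 20000 nM for now.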

Compound 3, half-maximal inhibitory concentration: 3720 nM
Compound 3: middle estimate off by 2.6-fold (0.41 log units), on the high side; the whole stated range lies above it.
By their numbers in this assay, from the lowest: compound 3; then compounds 1 and 2 (each within the scatter of the next).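

With chloro held constant, placing quinolin-3-yl rather than 1H-indol-6-yl on the amine nitrogen gives a 2.9-fold lower number from compound 2 to compound 3 (0.47 log units; beyond the scatter) in this assay, so this position affects the read-out, which compounds 1 and 2 could not show because they differ in two places. With quinolin-3-yl held constant, chloro in place of methoxy on an aromatic carbon gives a 2.5-fold lower number from compound 1 to compound 3 (0.40 log units; beyond the scatter), so that place matters too. Nothing available explains either step. Still open, from the compounds shown here alone, is how a plain phenyl on the amine nitrogen, or fluoro or methyl on the aromatic carbon, would compare.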